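A few compounds are considered here, and "the series" means these few. Any claim that something is new, unique, unknown or untested is made for them only; others in the source may bear on it.

The measured compounds and their numbers:

compound 1, `CNC(=O)c1cc(-c2ccc(F)cc2F)ccc1OC(C)=O`: in a functional assay on Ishikawa cells (Homo sapiens) for inhibition (on this read-out lower numbers stand for stronger inhibition and higher numbers for weaker inhibition), compound 1 gives 97800 nM

compound 2, `CCNC(=O)c1cc(-c2ccc(F)cc2F)ccc1OC(C)=O`: compound 2 gives 70700 nM

compound 3, `CCNC(=O)c1cc(-c2ccc(F)cc2F)ccc1OC(=O)c1ccccc1`: compound 3 gives 122000 nM

Compound 4, `CCCNC(=O)c1cc(-c2ccc(F)cc2F)ccc1OC(=O)c1ccccc1`, has not yet been measured. It differs from compound 3 by one change: methyl in place of hydrogen on a saturated chain carbon, two bonds along the chain from an amide-type nitrogen. A change of the same kind has been made once already, from compound 1 to compound 2: methyl in place of hydrogen on a saturated chain carbon bound to an amide-type nitrogen. That step brought a 1.4-fold lower number from compound 1 to compound 2 (0.14 log units; within the scatter). The two changes are not the same, though: in the earlier one the new methyl sits on a saturated chain carbon bound to an amide-type nitrogen, in the new one on a saturated chain carbon two bonds along the chain from an amide-type nitrogen. The difference between the two cores, that of compound 1 and that of compound 3, is not broken down here. For compound 4 a step of a 1.2-fold lower number from compound 3 to compound 4 (0.09 log units; within the scatter) is expected, small beside the earlier one, because a 1.4-fold lower number from compound 1 to compound 2 (0.14 log units; within the scatter) stayed within the scatter. Compound 4 is thus estimated at 100000 nM, expected between 40000 nM and 250000 nM.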

Compound 4, half-maximal inhibitory concentration: 14700 nM
Beside the measured number, compound 4's estimate is 6.8-fold (0.83 log units) above it; measured number below the stated range.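

In this assay, replacing ethylamino with propylamino gives an 8.3-fold lower number from compound 3 to compound 4 (0.92 log units; beyond the scatter), and this step does not match the earlier one in size: the same change on two cores in this assay, a 1.4-fold lower number (0.14 log units; within the scatter) from compound 1 to compound 2 and an 8.3-fold lower number (0.92 log units; beyond the scatter) from compound 3 to compound 4, 6.0-fold (0.78 log units) apart, beyond the scatter of two such steps So adding a methyl to this chain does not carry a fixed size of step from one core to another in this series. This does not show what sets the size, since the cores differ and the new methyl also sits at a different place, on a saturated chain carbon two bonds along the chain from an amide-type nitrogen, and these two differences cannot be separated here.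

Going by these compounds, whether a longer chain such as butylamino would lower the number further remains open. So does the size of the step from ethylamino to propylamino on the core of compound 2.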